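Fluorophenyl and nitrophenyl amides on a shared sulfonamide core

A few compounds are considered here, and "the series" means these few. Any claim that something is new, unique, unknown or untested is made for them only; others in the source may bear on it.

Measured so far:
- compound 1, `O=C(NCc1ccc(CNS(=O)(=O)c2ccccc2)cc1)c1cccc(F)c1`, 100 nM
- compound 2, `O=C(NCc1ccc(CNS(=O)(=O)c2ccccc2)cc1)c1ccc(F)cc1`, 100 nM
- compound 3, `O=C(NCc1ccc(CNS(=O)(=O)c2ccccc2)cc1)c1ccc([N+](=O)[O-])cc1`, 100 nM

In an assay on MDA-MB-231 cells for binding affinity to C-X-C chemokine receptor type 4 (Homo sapiens), read by immunofluorescence and microscopy, with stated times of 10 min and 30 min (a higher number here means that more compound is needed for the effect, a lower number that less compound is needed), compound 3 stands level with compounds 1 and 2 at the digits shown. The step of no change at the digits printed from compound 1 to compound 3 (within the scatter) and the step of no change at the digits printed from compound 2 to compound 3 (within the scatter) both lie within the scatter, as does no change at the digits printed from compound 1 to compound 2 (within the scatter), so among the three measured compounds the group on the carbonyl carbon has not moved the reading.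

Compound 4, `O=C(NCc1ccc(CNS(=O)(=O)c2ccccc2)cc1)c1ccccc1F`, is not yet measured. It differs from compound 3 as follows: 2-fluorophenyl in place of 4-nitrophenyl on a carbonyl carbon. For the measured compounds named here, the steps that bear on this change are no change at the digits printed from compound 1 to compound 2 (within the scatter), where one fluorophenyl replaced another, and no change at the digits printed from compound 1 to compound 3 (within the scatter), where nitrophenyl replaced fluorophenyl; both were flat. A further fluorophenyl on the same carbonyl carbon is therefore expected to give no step beyond the scatter in this assay.

Compound 4 is estimated at 100 nM, within 50 nM to 200 nM, meaning an expected step of no change at the digits printed from compound 3 to compound 4 (within the scatter).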

Compound 4, effective concentration (reported as EC, without a stated level of effect): 1000 nM
For compound 4 the middle estimate is 10-fold (1.00 log units) below the measured one; measured number outside the range, above it.
By their numbers in this assay, from the lowest: compounds 1, 2 and 3 (each within the scatter of the next); then compound 4.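

In this assay the group on the carbonyl carbon proves able to move the reading: among the fluorophenyl amides there is a 10-fold higher number from compound 1 to compound 4 (1.00 log units; beyond the scatter) and also a 10-fold higher number from compound 2 to compound 4 (1.00 log units; beyond the scatter) in a single change of group. So where the fluorine sits on the ring matters here, with 2-fluorophenyl parting from both 3-fluorophenyl and 4-fluorophenyl. The same group also parts from 4-nitrophenyl, with a 10-fold higher number from compound 3 to compound 4 (1.00 log units; beyond the scatter) and thus a limit on the flat picture, which held only for the three earlier groups. Nothing available here accounts for this rise.

On these data alone, it remains open whether a chlorophenyl, a methoxyphenyl or an unsubstituted phenyl on the carbonyl carbon would read like compound 4 or like compounds 1, 2 and 3. As far as these compounds go, all four compounds share one core, so whether the step carries over to another core also stays unknown.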